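The compounds below may be only part of what the source reports. "The series", "measured", "known", "first", "only" and "open" are said of these compounds alone.

In an ADME assay on microsomes from liver (Homo sapiens) for metabolic stability, with a stated time of 10 min, tested at 0.5 uM (a lower number here means that less of the compound is left, a higher number that more of the compound is left), compound 1 (`C[C@H](NC(=O)c1cnn2cccnc12)c1cc2cc(Cl)cc(C(=O)O)c2o1`) gives 100%, and compound 2 (`O=C(O)c1cc(Cl)cc2cc(CNC(=O)c3cnn4cccnc34)oc12`) gives 100%, level with compound 1. Compound 3 (`O=C(O)c1c(O)c(Cl)cc2cc(CNC(=O)c3cnn4cccnc34)oc12`) differs from compound 2 by one change: hydroxy in place of hydrogen on an aromatic carbon. Among the compounds with values here, the only measured step, no change at the digits printed from compound 1 to compound 2 (within the scatter), lies at a different place in the structure, so it offers weak guidance for this change. With compound 2 at 100%, no shift beyond the scatter is expected, though a small loss remains possible. The expected step is a number 5 percentage points lower from compound 2 to compound 3 (within the scatter). For compound 3, the estimated value is 95%, within an expected range of 82% to 100%.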

Compound 3, percent of the compound remaining: 98%
Compound 3: middle estimate off by 3 percentage points, on the low side; measured number inside the range.
By their numbers in this assay, from the lowest: compounds 3, 1 and 2 (each within the scatter of the next).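

Within the data shown here, the step of a number 2 percentage points lower from compound 2 to compound 3 (within the scatter) in this assay is the first reading of a change on the aromatic ring, at a carbon ortho to a carboxy group and ortho to a chloro group. Adding a hydroxy here leaves the compound's stability in this test as high as before, just as the earlier change on the chain carbon did. Nothing shown explains this result. Going by these compounds, whether a methoxy group or an amine at this carbon would also leave the number in place remains open. So does the effect of this hydroxy when the chain carbon carries a methyl.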